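The source may hold more compounds than are shown below. What is called first, only, known or untested is meant among the compounds shown, and "the series" means these compounds.

Measured compounds:
compound 1 `CCOC(=O)C1=Cc2ccccc2OC1(OCc1cn(-c2ccc(F)cc2)nn1)C(F)(F)F` — 8900 nM
compound 2 `O=C(O)C1=Cc2ccccc2OC1(OCc1cc(-c2ccc3ccccc3c2)no1)C(F)(F)F` — 141000 nM

In a functional assay on DU-145 cells (Homo sapiens) for inhibition, read by MTT assay, with a stated time of 24 h (a higher number here means a weaker inhibitor, a lower number a stronger inhibitor), compound 1 gives 8900 nM, the lower of the two numbers; compound 2 gives 141000 nM, and the gap between them lies beyond the scatter, though the two structures differ in more than one place. Compound 3 `CCOC(=O)C1=Cc2ccccc2OC1(OCc1cn(-c2ccc([N+](=O)[O-])cc2)nn1)C(F)(F)F` has not yet been measured. It differs from compound 1 by nitro in place of fluoro on an aromatic carbon. Among the measured compounds shown here, with no measured pair showing such a change, the step expected from compound 1 to compound 3 is small, none beyond the scatter, in either direction: a 1.1-fold lower number from compound 1 to compound 3 (0.05 log units; within the scatter). Compound 3 is therefore estimated at 8000 nM, within 2500 nM to 25000 nM.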

Compound 3, half-maximal inhibitory concentration: > 150000 nM
Compound 3 was reported as a limit; the forecaster's own chance of this, stated with the estimate: 5%; middle value at least 18-fold (1.27 log units) away from the limit.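

The earlier compounds shown here gave no sign of how much this position matters, but the 4-fluorophenyl of compound 1 proves far from indifferent to what it carries: in this assay, nitro in place of fluoro, para to a large group, gives an at least 16-fold higher number from compound 1 to compound 3 (1.22 log units; beyond the scatter). The change thus weakens the compound beyond the scatter. For compound 3, the reading of > 150000 nM is a limit of the assay and not a number: the limit of > 150000 nM in this assay, at which 1 of the 3 values shown sits.

With only fluoro and nitro shown at this position, it remains open whether the loss is particular to nitro. An amine or a nitrile on the same aromatic carbon would help to tell.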